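Amide nitrogen amino swap: expected solubility of compound 4

The compounds below may be only part of what the source reports. "The series", "measured", "known", "first", "only" and "open" are said of these compounds alone.

Among the three compounds measured in a physicochemical assay for solubility, at pH 6 (a higher number here means a more soluble compound, a lower number a less soluble compound), compound 3 `CNC(=O)c1ccc(-c2cc(-c3ccc(C#N)cc3)nc(-c3ccco3)c2)cc1` gives 25000 nM. Its nearest neighbour is compound 2 `N#Cc1ccc(-c2cc(-c3ccc(-c4nnn[nH]4)cc3)cc(-c3ccco3)n2)cc1`, which gives 18000 nM, a difference within the scatter, while compound 1 `N#Cc1ccc(-c2cc(-c3ccc(C(N)=O)cc3)cc(-c3cnco3)n2)cc1` gives 250000 nM, a gap beyond the scatter. Compound 4 `N#Cc1ccc(-c2cc(-c3ccc(C(=O)NN)cc3)cc(-c3ccco3)n2)cc1` differs from compound 3 by amino in place of methyl on an amide-type nitrogen. Going by the values given here, the only single-point step recorded, a 1.4-fold higher number from compound 2 to compound 3 (0.14 log units; within the scatter), is within the scatter and concerns a different site, so nothing measured shows how this exchange moves the numbers. The expected step is a 1.4-fold higher number from compound 3 to compound 4 (0.15 log units; within the scatter), nothing beyond the scatter. The estimate for compound 4 is 35000 nM, with a range of 12000 nM to 100000 nM.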

Compound 4, solubility: 500000 nM
Beside the measured number, compound 4's estimate is 14-fold (1.15 log units) below it; the measured number lies above the stated range.
By their numbers in this assay, from the lowest: compounds 2 and 3 (each within the scatter of the next); then compounds 1 and 4 (each within the scatter of the next).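

Amino in place of methyl on an amide-type nitrogen gives, in this assay, a 20-fold higher number from compound 3 to compound 4 (1.30 log units; beyond the scatter), the first single-point step shown at this position and the first beyond the scatter. Replacing the 1H-tetrazol-5-yl on the aromatic carbon with aminocarbamoyl gives a 28-fold higher number from compound 2 to compound 4 (1.44 log units; beyond the scatter), whereas methylcarbamoyl at that carbon gave only a 1.4-fold higher number from compound 2 to compound 3 (0.14 log units; within the scatter), within the scatter. Nothing available accounts for the size of this change.

Going by these compounds, whether a hydroxyl group or a longer chain on that nitrogen would give a step of similar size remains open. So does whether the same exchange would act alike on the core of compound 1.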